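Trimethoxyphenyl variant of a weakly active quinazoline-linked amide series

The source may report more compounds than this note shows. Statements on the series, on what has been measured and on what is new or still open speak of the compounds shown alone.

Measured so far in a functional assay on NCI-H1975 cells (Homo sapiens) for inhibition, read by MTT assay, with a stated time of 72 h; on this read-out lower numbers stand for stronger inhibition and higher numbers for weaker inhibition:
compound 1 `O=C(CSc1nc(Nc2ccccc2)c2ccccc2n1)Nc1cccc(Cl)c1` gives 8460 nM;
compound 2 `C=CC(=O)Nc1cccc(NC(=O)CSc2nc(Nc3ccccc3Cl)c3ccccc3n2)c1` gives 10000 nM;
compound 3 `C=CC(=O)Nc1cccc(NC(=O)CSc2nc(Nc3cccc(C)c3)c3ccccc3n2)c1` gives 12100 nM.

Compound 3 has the highest number of the three, yet its gap to compound 2 is within the scatter, as is its gap to compound 1, so all three read as equally weak. Compound 4 `C=CC(=O)Nc1cccc(NC(=O)CSc2nc(Nc3cc(OC)c(OC)c(OC)c3)c3ccccc3n2)c1` differs from compound 3 only by 3,4,5-trimethoxyphenyl in place of 3-methylphenyl on a nitrogen on an aromatic ring. Among the compounds with values here, the one measured step at this place, a 1.2-fold higher number from compound 2 to compound 3 (0.08 log units; within the scatter), changed nothing beyond the scatter, which suggests this position tolerates change without moving the read-out. Compound 4 is therefore expected near compound 3, with a 1.0-fold lower number from compound 3 to compound 4 (0.00 log units; within the scatter). The estimate for compound 4 in this assay is 12000 nM, in a range from 5000 nM to 30000 nM.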

Compound 4, half-maximal inhibitory concentration: > 50000 nM
Compound 4 was reported as a limit; the forecaster's own chance of this, stated with the estimate: 15%; middle value at least 4.1-fold (0.61 log units) away from the limit.
By their numbers in this assay, from the lowest: compounds 1, 2 and 3 (each within the scatter of the next). At a limit, above all of these: compound 4.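

The earlier step suggested that this position tolerates change, but the trimethoxyphenyl group shows that it does not tolerate every change. In this assay, 3,4,5-trimethoxyphenyl in place of 3-methylphenyl gives an at least 4.1-fold higher number from compound 3 to compound 4 (0.61 log units; beyond the scatter), and in place of 2-chlorophenyl it gives an at least 5.0-fold higher number from compound 2 to compound 4 (0.69 log units; beyond the scatter). Within the data shown here, these are the first changes at this place to go beyond the scatter, and both point to weaker inhibition. The value of compound 4 is a limit, not a number: the limit of > 50000 nM in this assay, at which 1 of the 4 values shown sits.

Going by these compounds, whether a phenyl ring with a single methoxy group, or one carrying an amine or a carboxylic acid, would stay near compound 3 remains open.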